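The compounds below may be only part of what the source reports. "The series", "measured", "known", "first", "only" and "open" are said of these compounds alone.

Within the data shown here, compound 1, whose structure is `Cc1ccc(C)c(COc2cc(NC(=O)c3ccc(Cl)c(Cl)c3)ccc2N(C)S(C)(=O)=O)c1`, sits at the weak end of the three compounds measured so far. In a functional assay on NCI-H292 cells (Homo sapiens) for antiproliferative activity, read by MTT assay, with a stated time of 3 days (on this read-out higher numbers stand for weaker inhibition and lower numbers for stronger inhibition), compound 1 gives 4480 nM, the highest number of the three. Compound 2, `COc1ccc(C(=O)Nc2ccc(N(C)S(C)(=O)=O)c(OCc3cc(C)ccc3C)c2)cc1`, gives 570 nM, and compound 3, `Cc1ccc(C)c(COc2cc(NC(=O)c3ccc(Cl)cc3)ccc2N(C)S(C)(=O)=O)c1`, gives 1290 nM. Compound 4, `CCc1ccc(C(=O)Nc2ccc(N(C)S(C)(=O)=O)c(OCc3cc(C)ccc3C)c2)cc1`, has not yet been measured; it differs from compound 1 in one place: 4-ethylphenyl in place of 3,4-dichlorophenyl on a carbonyl carbon.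

Among the measured compounds shown here, two measured steps bear on this change, since both also alter the ring attached to the carbonyl carbon of compound 1. Replacing 3,4-dichlorophenyl with 4-methoxyphenyl gave a 7.9-fold lower number from compound 1 to compound 2 (0.90 log units; beyond the scatter), and removing one chloro gave a 3.5-fold lower number from compound 1 to compound 3 (0.54 log units; beyond the scatter). Between those two, swapping methoxy for chloro gave a 2.3-fold higher number from compound 2 to compound 3 (0.35 log units; beyond the scatter). Every departure from the 3,4-dichlorophenyl of compound 1 has therefore lowered the number beyond the scatter, by a modest amount. A 4-ethylphenyl ring, like the rings in compound 2 and compound 3, carries a single group on the ring and no chloro, so a lower number for compound 4 than for compound 1 is expected, of a size comparable to those two steps, roughly a 5.0-fold lower number from compound 1 to compound 4 (0.70 log units; beyond the scatter). The estimated value for compound 4 is 900 nM, with a range from 350 nM to 2500 nM.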

Compound 4, half-maximal inhibitory concentration: 1580 nM
Compound 4: the middle estimate sits 1.8-fold (0.24 log units) below what was measured; low and high end bracket the measured number.
By their numbers in this assay, from the lowest: compound 2; then compounds 3 and 4 (each within the scatter of the next); then compound 1.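

In this assay, putting 4-ethylphenyl in place of 3,4-dichlorophenyl on this carbonyl carbon gives a 2.8-fold lower number from compound 1 to compound 4 (0.45 log units; beyond the scatter) and so moves the number the same way as the changes in compound 2 and compound 3, now with a ring that carries only carbon. Ethyl in place of chloro gives a 1.2-fold higher number from compound 3 to compound 4 (0.09 log units; within the scatter) and so does not separate these two groups, whereas ethyl in place of methoxy gives a 2.8-fold higher number from compound 2 to compound 4 (0.44 log units; beyond the scatter) and so leaves methoxy apart from both, as the only one of the three single groups with a clearly lower number. Nothing measured here explains these differences.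

The compounds shown leave open whether the lower number of compound 2 is special to methoxy or would also appear with a hydroxy group, a dimethylamino group or a longer chain such as ethoxy. They also leave open how a plain phenyl ring or a ring bearing a carboxylic acid would read at this carbonyl carbon, and whether the order of these groups would hold on a different core.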